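Replacing Chloro with Hydroxy on a Shared Core

The source may hold more compounds than are shown below. What is called first, only, known or untested is meant among the compounds shown, and "the series" means these compounds.

In a functional assay on P388 cells (Mus musculus) for antiproliferative activity, read by colorimetric assay and MTT assay (a lower number here means a stronger inhibitor, a higher number a weaker inhibitor), compound 3 (`Nc1ccc(S(=O)(=O)Nc2cccc3cc(Cl)[nH]c23)cc1`) gives 2.2 ug/mL, the lowest number among the values shown. Where compound 3 has chloro, compound 2 (`Nc1ccc(S(=O)(=O)Nc2cccc3cc[nH]c23)cc1`) has hydrogen and gives 14 ug/mL. Among the compounds with values here, the only measured step at this place is a 6.4-fold lower number from compound 2 to compound 3 (0.80 log units; beyond the scatter).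

Compound 4 (`Nc1ccc(S(=O)(=O)Nc2cccc3cc(O)[nH]c23)cc1`) remains to be measured. Its structural change is hydroxy in place of chloro on an aromatic carbon, next to the ring nitrogen. Compound 1 (`O=[N+]([O-])c1ccc(S(=O)(=O)Nc2cccc3cc(O)[nH]c23)cc1`), which carries hydroxy in that place, returns only a limit, > 100 ug/mL.

Within the data shown here, no measured step runs directly from chloro to hydroxy, so the expectation rests on two observations: the size of a 6.4-fold lower number from compound 2 to compound 3 (0.80 log units; beyond the scatter), and the absence of a number for compound 1. A step of similar size toward a higher number is therefore expected in this assay. The expected change is a 6.8-fold higher number from compound 3 to compound 4 (0.83 log units; beyond the scatter). Compound 4 is estimated at 15 ug/mL, within an expected range of 4 ug/mL to 70 ug/mL.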

Compound 4, half-maximal inhibitory concentration: 1.2 ug/mL
Estimate against measurement, compound 4: 13-fold (1.10 log units) above, outside the stated range (below it).
By their numbers in this assay, from the lowest: compounds 4 and 3 (each within the scatter of the next); then compound 2. At a limit, above all of these: compound 1.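

Exchanging chloro for hydroxy next to the ring nitrogen gives no distinction in this assay, with a 1.8-fold lower number from compound 3 to compound 4 (0.26 log units; within the scatter). Against hydrogen at the same place, hydroxy gives a 12-fold lower number from compound 2 to compound 4 (1.07 log units; beyond the scatter), so chloro and hydroxy both depart from hydrogen in the same direction. Compound 1 carries the same hydroxy, so hydroxy at this place does not by itself go with its poor reading, and amino in place of nitro gives an at least 83-fold lower number from compound 1 to compound 4 (1.92 log units; beyond the scatter), a step read from a limit: the limit of > 100 ug/mL in this assay, at which 1 of the 4 values shown sits.

The compounds shown leave open whether a methoxy group or an amine at this place would match hydroxy and chloro. They also leave open whether the step from nitro to amino holds with chloro or hydrogen at this place; nitro appears here only alongside hydroxy.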